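A few compounds are considered here, and "the series" means these few. Any claim that something is new, unique, unknown or untested is made for them only; others in the source may bear on it.

In an assay on isolated protein for binding affinity to leukotriene B4 receptor (Homo sapiens), tested at 0.1 uM (on this read-out lower numbers stand for less inhibition and higher numbers for more inhibition at the one concentration tested (going by the name of the read-out)), compound 2 `CCc1cc(C(C)=O)c(O)cc1OCCCCCCCC(C)(C)C#N` gives 6%, the lower of the two numbers recorded, though the gap to compound 1 `CCc1cc(C(C)=O)c(O)cc1OCCCC(C)(C)C#N`, which gives 13%, lies within the scatter. Compound 3 `CCc1cc(C(C)=O)c(O)cc1OCCCCCC(C)(C)C(=O)O` differs from compound 2 by 1-carboxy-1-methylethyl in place of 3-cyano-3-methylbutyl on a saturated chain carbon, five bonds along the chain from an oxygen on an aromatic ring. Within the data shown here, no measured pair isolates such a change, so the step is expected to be small: it is estimated as a number 8 percentage points higher from compound 2 to compound 3 (within the scatter), a rise that would stay within the scatter. On that basis compound 3 is expected to reach 14% in this assay, with a range from 0% to 40%.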

Compound 3, a percentage reported as inhibition, at one concentration (the size of the read-out at that concentration, not a potency): 20%
Compound 3: middle estimate off by 6 percentage points, on the low side; the measured number falls inside the stated range.
By their numbers in this assay, from the lowest: compounds 2, 1 and 3 (each within the scatter of the next, the first and the last beyond it).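

In this assay, among these compounds, 1-carboxy-1-methylethyl in place of 3-cyano-3-methylbutyl at this chain carbon gives the first step beyond the scatter (a number 14 percentage points higher from compound 2 to compound 3 (beyond the scatter)). The comparison with the shorter nitrile stays within the scatter (a number 7 percentage points higher from compound 1 to compound 3 (within the scatter)), so the carboxylic acid clearly separates only from the longer nitrile. Nothing at hand explains either step.

Open, from the compounds shown here alone, is whether a carboxylic acid on a shorter or longer chain would change the reading. Also open, going by these compounds, is how an amide or a tetrazole would compare at this position.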